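Removing a methyl from a stilbene: expected cytotoxicity

This account rests on a few compounds, and the source may have more. Where it says the series, first, only, none or still open, it means among the compounds named here.

Compound 2 `COc1cc(O)cc(/C=C/c2cccc(OC)c2OC)c1` and compound 1 `COc1c(O)cccc1/C=C/c1cc(O)cc(O)c1` were both tested in a functional assay on HepG2 cells (Homo sapiens) for cytotoxicity, read by MTT assay, with a stated time of 24 h; on this read-out lower numbers stand for stronger inhibition and higher numbers for weaker inhibition. For compound 2 this assay reports only a limit, > 100000 nM. For compound 1 as well, this assay gives only a limit, > 100000 nM. This is the limit of > 100000 nM in this assay, at which 2 of the 2 values shown sit, so neither compound shows measurable cytotoxicity here. Compound 3 `COc1cc(O)cc(/C=C/c2cccc(O)c2OC)c1` has not yet been measured; it differs from compound 2 by hydrogen in place of methyl on an oxygen on an aromatic ring. Among the compounds with values here, no measured pair shares this change, so no step size is known. The step that the limit leaves unreadable from compound 2 to compound 3 is expected to be none beyond the scatter. Compound 3 is therefore estimated at 150000 nM, within 50000 nM to 500000 nM.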

Compound 3, half-maximal inhibitory concentration: 90800 nM
Compound 3: middle estimate off by 1.7-fold (0.22 log units), on the high side; the range from low to high includes it.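

In this assay, within the data shown here, compound 3 is the first compound here to give a number and not a limit, so the effect of this change can begin to be sized. Hydrogen in place of methyl on an oxygen on an aromatic ring gives an at least 1.1-fold lower number from compound 2 to compound 3 (0.04 log units; that floor lies within the scatter), and methyl in place of hydrogen on an oxygen on an aromatic ring gives an at least 1.1-fold lower number from compound 1 to compound 3 (0.04 log units; that floor lies within the scatter). The real size of both steps cannot be read, because each starts from a limit: the limit of > 100000 nM in this assay, at which 2 of the 3 values shown sit.

As far as these compounds go, whether an ethoxy group or an amine at this place would move the number further remains open.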